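This account rests on a few compounds, and the source may have more. Where it says the series, first, only, none or still open, it means among the compounds named here.

Of the compounds shown here, two of a shared core have so far been tested in a functional assay on HepG2 cells (Homo sapiens) for cytotoxicity, read by MTT assay, with a stated time of 72 h; a lower number here means a stronger inhibitor, a higher number a weaker inhibitor. Compound 1 `COc1ccc2ccc(=O)oc2c1C1=NN(C(N)=O)C(c2cccs2)C1` carries a thiophen-2-yl group on the saturated ring carbon and a carboxamide on the ring nitrogen, and in this assay compound 1 gives 26 nM. Compound 2 `COc1ccc2ccc(=O)oc2c1C1=NN(c2ccccc2)C(c2ccccc2)C1` carries a phenyl group in both of those places, and in this assay compound 2 gives 73 nM. Compound 2 thus stands at the higher of the two numbers, and its gap to compound 1 is beyond the usual scatter. Among the compounds with values here, the two compounds differ in two places at once, so the two values say only that the pair of thiophen-2-yl and carboxamide sits lower than the pair of two phenyl groups.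

Compound 3 `COc1ccc2ccc(=O)oc2c1C1=NN(c2ccccc2)C(c2cccs2)C1` has not yet been measured. It differs from compound 2 in one place only: thiophen-2-yl in place of phenyl on a saturated ring carbon. Within the data shown here, since compound 1, the only compound bearing a thiophen-2-yl group, gives the lower number, a modest step toward a lower number is expected, though one that may not exceed the scatter. The expected step is a 1.5-fold lower number from compound 2 to compound 3 (0.16 log units; within the scatter), and compound 3 is estimated at 50 nM, within a range from 20 nM to 150 nM.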

Compound 3, half-maximal inhibitory concentration: 15 nM
Compound 3: the middle estimate sits 3.3-fold (0.52 log units) above what was measured, outside the stated range (below it).
By their numbers in this assay, from the lowest: compounds 3 and 1 (each within the scatter of the next); then compound 2.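

With the phenyl group on the ring nitrogen kept, thiophen-2-yl in place of phenyl on a saturated ring carbon gives in this assay a 4.9-fold lower number from compound 2 to compound 3 (0.69 log units; beyond the scatter) and lies beyond the scatter, so a change at this one position is enough to move the number, something the two earlier compounds, which differ in two places at once, could not show. With thiophen-2-yl held fixed, phenyl in place of carbamoyl on an amine nitrogen in a ring gives a 1.7-fold lower number from compound 1 to compound 3 (0.24 log units; within the scatter) and lies within the scatter, so these two groups on the ring nitrogen cannot be told apart in this assay while thiophen-2-yl stays in place. Nothing available here explains why the exchange of phenyl for thiophen-2-yl moves the number.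

Whether the same exchange would have a similar effect with carbamoyl on the ring nitrogen remains open, since no compound shown pairs that group with phenyl on the saturated ring carbon. On these data alone, it is also open whether another group at that carbon, such as furan-2-yl, pyridin-2-yl or a simple methyl, would give a number close to that of thiophen-2-yl or of phenyl.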